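This account rests on a few compounds, and the source may have more. Where it says the series, first, only, none or still open, it means among the compounds named here.

In an ADME assay on Vero cells (Chlorocebus sabaeus) for cytotoxicity, read by resazurin assay, with a stated time of 3 days (a lower number here means a stronger inhibitor, a higher number a weaker inhibitor), compound 3 `CCCNC(=O)Nc1cc2nc(C3CCCCC3)[nH]c2cc1N(CC)CC` reaches only a limit, > 100 ug/mL. Compound 2 `CCN(CC)c1cc2[nH]c(C3CCCCC3)nc2cc1NC(=O)c1ccc(OC(F)(F)F)cc1` likewise stops at a limit in this assay, > 100 ug/mL. For compound 1 `CCCCCC(=O)Nc1cc2nc(C3CCCCC3)[nH]c2cc1N(CC)CC` this assay gives "not determined" (no result reported). Within the data shown here, the one step between measured compounds, a step that the two limits leave unreadable from compound 2 to compound 3, has no readable size. Compound 4 `CCN(CC)c1cc2[nH]c(C3CCCCC3)nc2cc1NC(=O)c1ccc(Br)cc1` differs from compound 3 by 4-bromophenyl in place of propylamino on a carbonyl carbon. Among the measured compounds shown here, no measured step bears on this change with a readable size; the only guide is the limit of > 100 ug/mL in this assay, at which 2 of the 3 values shown sit, so no step beyond the scatter is expected, and a further limit rather than a number seems the most likely outcome. Compound 4 is therefore expected at about 100 ug/mL, with a range from 40 ug/mL to 250 ug/mL. The expected step of a number no higher from compound 3 to compound 4 (the limit leaves the size open) is essentially nil.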

Compound 4, half-maximal inhibitory concentration: > 100 ug/mL
Compound 4: a limit, no number; the forecaster's own chance of this, stated with the estimate: 70%; the middle value sits exactly at the limit.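

The steps from compound 4 to compound 2 and compound 3 cannot be read, as all three values are limits, not numbers: the limit of > 100 ug/mL in this assay, at which 3 of the 4 values shown sit.

From the compounds shown here alone, whether any group on the carbonyl carbon would give an actual number in this assay stays open.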